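Ester to benzyl amide on the aminopentyl scaffold

The source may hold more compounds than are shown below. What is called first, only, known or untested is meant among the compounds shown, and "the series" means these compounds.

Measured so far:
compound 1 `CN(C)C1=Nc2ccccc2C(CC(=O)NCc2ccc(NS(=O)(=O)c3ccc(F)cc3)cc2)N1c1ccccc1` — 430 nM
compound 2 `COC(=O)CC1c2ccccc2N=C(NCCCCCN)N1c1ccccc1` — 1840 nM
compound 3 `COC(=O)CC1c2ccccc2N=C(NCCCCCNC(=O)OC(C)(C)C)N1c1ccccc1` — 2020 nM

In an assay on HEK293 cells for inhibition of Voltage-dependent T-type calcium channel subunit alpha-1G (Homo sapiens) (a higher number here means a weaker inhibitor, a lower number a stronger inhibitor), compound 2 gives 1840 nM, the second highest of the three numbers shown. For the measured compounds named here, its nearest neighbour is compound 3, and the only single-point step in the set, a 1.1-fold higher number from compound 2 to compound 3 (0.04 log units; within the scatter), shows that a tert-butoxycarbonyl on the amine nitrogen leaves the read-out where it was. The furthest value is that of compound 1, which in this assay gives 430 nM; compound 1 differs from compound 2 in more than one place, so only the two values can be compared, not a step.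

Compound 4 `NCCCCCNC1=Nc2ccccc2C(CC(=O)NCc2ccccc2)N1c1ccccc1` is not yet measured. It differs from compound 2 in one place: benzylamino in place of methoxy on a carbonyl carbon. Going by the values given here, no measured step covers this change; the ester is kept in both compound 2 and compound 3, and the step between them concerns a different position. Among the compounds with values here, compound 1, the one measured compound that carries a benzylcarbamoyl group on the same chain, sits at the low end of the set, but it also carries a dimethylamino group in place of the aminopentyl chain, so its value is only a loose pointer.

On that basis the number for compound 4 is expected to come out somewhat lower than for compound 2, a step of about a 2.0-fold lower number from compound 2 to compound 4 (0.31 log units; beyond the scatter), with wide uncertainty. The estimate for compound 4 in this assay is 900 nM, with a range from 300 nM to 3000 nM.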

Compound 4, half-maximal inhibitory concentration: 3130 nM
Compound 4: middle estimate off by 3.5-fold (0.54 log units), on the low side; measured number above the stated range.
By their numbers in this assay, from the lowest: compound 1; then compounds 2, 3 and 4 (each within the scatter of the next).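

In this assay, benzylamino in place of methoxy on the carbonyl carbon gives a 1.7-fold higher number from compound 2 to compound 4 (0.23 log units; within the scatter), so this position accepts a group with a six-membered aromatic ring and a hydrogen-bond donor, and the ester is not needed to hold a read-out of this size; the same holds so far for the other single-place change, a 1.1-fold higher number from compound 2 to compound 3 (0.04 log units; within the scatter), and neither step separates its two compounds. Compound 1, at 430 nM, differs from compound 4 in more than one place, so no part of its value can be assigned to the benzylcarbamoyl group on the evidence of this pair. No measurement on hand bears on the cause of this result.

Open at the carbonyl carbon is how a carboxylic acid or a morpholine amide would read, and whether a chain longer than aminopentyl would alter the picture. Also open, from the compounds shown here alone, is how the plain benzylcarbamoyl group reads alongside the dimethylamino group of compound 1, which would separate the contribution of the sulfonamide on its benzyl ring from that of the chain.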